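The source may report more compounds than this note shows. Statements on the series, on what has been measured and on what is new or still open speak of the compounds shown alone.

Working notes on the series.

Compound 1 `O=C(Nc1n[nH]c2cc(-c3cn([C@@H]4CN[C@H](C(=O)Nc5ccc(Cl)cc5Cl)C4)nn3)ccc12)C1CC1` and compound 2 `O=C(Nc1n[nH]c2cc(-c3cn([C@@H]4CN[C@H](C(=O)Nc5ccc(Br)cc5)C4)nn3)ccc12)C1CC1` are built on one core; compound 3 `CC(C)(C)OC(=O)N1C[C@@H](n2cc(-c3ccc4nc(N)sc4n3)nn2)C[C@H]1C(=O)Nc1ccc(Cl)cc1Cl` and compound 4 `CC(C)(C)OC(=O)N1C[C@@H](n2cc(-c3ccc4nc(N)sc4n3)nn2)C[C@H]1C(=O)Nc1ccc(Br)cc1` are built on another. How the core of compound 1 and the core of compound 3 differ is not broken down here.

In a functional assay on K562 cells (Homo sapiens) for inhibition, read by MTT assay, with a stated time of 48 h (on this read-out lower numbers stand for stronger inhibition and higher numbers for weaker inhibition), compound 1 gives 5340 nM. In this assay compound 2 gives 8080 nM. The change from compound 1 to compound 2 is 4-bromophenyl in place of 2,4-dichlorophenyl on an amide-type nitrogen, and the step it made is a 1.5-fold higher number from compound 1 to compound 2 (0.18 log units; within the scatter).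

In this assay compound 3 gives 8940 nM. The value of compound 3 lies within the scatter of both the value of compound 2 and the value of compound 1, so no order among the three measured compounds is drawn.

Compound 4 carries the same change, now on the core of compound 3: 4-bromophenyl in place of 2,4-dichlorophenyl on an amide-type nitrogen. The place is the same in both pairs, an amide-type nitrogen whose other neighbour is a carbonyl carbon, so the change is taken as the same change.

The step expected for this assay is a 1.3-fold higher number from compound 3 to compound 4 (0.13 log units; within the scatter), set beside the measured 1.5-fold higher number from compound 1 to compound 2 (0.18 log units; within the scatter). This rests on one earlier occurrence only, that from compound 1 to compound 2, whose step a 1.5-fold higher number from compound 1 to compound 2 (0.18 log units; within the scatter) itself lay within the scatter, so the direction is weakly supported and the range is kept wide. Compound 4 is thus expected to give about 12000 nM in this assay, estimated to fall between 5500 nM and 28000 nM.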

Compound 4, half-maximal inhibitory concentration: 29200 nM
Compound 4: the middle estimate sits 2.4-fold (0.39 log units) below what was measured; the whole stated range lies below it.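

On the core of compound 3, 4-bromophenyl in place of 2,4-dichlorophenyl on an amide-type nitrogen gives in this assay a 3.3-fold higher number from compound 3 to compound 4 (0.51 log units; beyond the scatter), so on this core the change gives a step that can be read as weaker inhibition. Set beside the earlier pair, the step shows no measurable dependence on the core: the same change on two cores in this assay, a 1.5-fold higher number (0.18 log units; within the scatter) from compound 1 to compound 2 and a 3.3-fold higher number (0.51 log units; beyond the scatter) from compound 3 to compound 4, 2.2-fold (0.33 log units) apart, within the scatter of two such steps. Among these compounds, this does not show that the step carries over with a fixed size, since only two pairs are available, the step on the core of compound 1 lies within the scatter, and a gap within the scatter neither proves the two steps equal nor rules out a real difference between them.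

The compounds shown leave open which part of the change goes with the step on the core of compound 3, the loss of the 2-chloro group or the exchange of the 4-chloro group for bromine, and a 4-chlorophenyl or an unsubstituted phenyl on the same amide-type nitrogen would separate the two. Also open, from the compounds shown here alone, is whether the step would recur on a third core, or with a non-halogen group such as 4-methoxyphenyl in the same place.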